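The source may hold more compounds than are shown below. What is called first, only, known or untested is meant among the compounds shown, and "the series" means these compounds.

Compound 1 `CN(C)CCn1cnnc1-c1cc(Oc2ccc(NC(=O)N/N=C/c3cccc(Br)c3)cc2F)ccn1`: 520 nM
Compound 2 `CN(C)CCn1cnnc1-c1cc(Oc2ccc(NC(=O)N/N=C/c3ccc(F)cc3Cl)cc2F)ccn1`: 720 nM
Compound 3 `CN(C)CCn1cnnc1-c1cc(Oc2ccc(NC(=O)N/N=C/c3ccc(F)cc3F)cc2F)ccn1`: 1930 nM

In a functional assay on NCI-H460 cells (Homo sapiens) for cytotoxicity, read by MTT assay, with a stated time of 72 h (a lower number here means a stronger inhibitor, a higher number a weaker inhibitor), compound 3 gives the highest number of the three, standing a 2.7-fold higher number from compound 2 to compound 3 (0.43 log units; beyond the scatter) and a 3.7-fold higher number from compound 1 to compound 3 (0.57 log units; beyond the scatter). Compound 4 `CN(C)CCn1cnnc1-c1cc(Oc2ccc(NC(=O)N/N=C/c3ccc(Cl)cc3Cl)cc2F)ccn1` has not yet been measured in this assay. It differs from compound 3 in one place: 2,4-dichlorophenyl in place of 2,4-difluorophenyl on a carbon with a double bond to nitrogen.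

For the measured compounds named here, one measured step bears directly on this change, the one in which fluoro replaced chloro on an aromatic carbon, which gave a 2.7-fold higher number from compound 2 to compound 3 (0.43 log units; beyond the scatter); read in the other direction, chloro in place of fluoro lowered the number. Compound 4 carries that exchange at two aromatic carbons rather than one. The other steps, a 1.4-fold higher number from compound 1 to compound 2 (0.14 log units; within the scatter) and a 3.7-fold higher number from compound 1 to compound 3 (0.57 log units; beyond the scatter), agree that a halogen-bearing phenyl on the carbon with a double bond to nitrogen shifts this assay only modestly. A step downward of modest size is therefore expected, a 3.5-fold lower number from compound 3 to compound 4 (0.55 log units; beyond the scatter), with compound 4 estimated at 550 nM, in the range 250 nM to 1200 nM.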

Compound 4, half-maximal inhibitory concentration: 130 nM
The estimate for compound 4 lay 4.2-fold (0.63 log units) above the measured number; the measured number lies below the stated range.
By their numbers in this assay, from the lowest: compound 4; then compounds 1 and 2 (each within the scatter of the next); then compound 3.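

In this assay, for the compounds shown here, the step from 2,4-difluorophenyl to 2,4-dichlorophenyl on the carbon with a double bond to nitrogen gave a 15-fold lower number from compound 3 to compound 4 (1.17 log units; beyond the scatter) and was the largest step seen at this place, so the choice of halogen matters here far more than the earlier compounds had suggested. The second chloro in place of fluoro still counted, giving a 5.5-fold lower number from compound 2 to compound 4 (0.74 log units; beyond the scatter), and 2,4-dichlorophenyl also surpassed 3-bromophenyl, with a 4.0-fold lower number from compound 1 to compound 4 (0.60 log units; beyond the scatter), which leaves compound 4 with the lowest number of the four. No measurement at hand accounts for why chloro and fluoro differ so much at this place.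

The compounds shown leave open whether 2,4-dibromophenyl would lower the number further. They also leave open whether a phenyl carrying methoxy or trifluoromethyl groups would match 2,4-dichlorophenyl at this place.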